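The compounds below may be only part of what the source reports. "The series", "measured", "known", "first", "only" and "open" are said of these compounds alone.

Working notes on the series. Compound 1 `O=C(C(Nc1ccccc1)c1ccc(C(F)(F)F)cc1)N1CCC[C@H]1c1ccccc1Cl`, compound 2 `O=C(C(Nc1ccccc1F)c1ccc(C(F)(F)F)cc1)N1CCCC1c1ccccc1F` and compound 3 `O=C(C(Nc1ccc(F)cc1)c1ccc(C(F)(F)F)cc1)N1CCCC1c1ccccc1Cl` share one core and differ in the substituents carried on their aromatic rings. In an assay on HEK293 cells for antagonist activity at transient receptor potential M8 protein (Canis lupus familiaris), read by fluorescence and calcium flux, with a stated time of 5 min (on this read-out higher numbers stand for weaker inhibition and lower numbers for stronger inhibition), compound 1 gives 41 nM. In this assay compound 2 gives 7 nM, the lowest of the three numbers. In this assay compound 3 gives 73 nM. Compound 2 stands apart from both neighbours: the gap to compound 1, its nearest, lies beyond the scatter, and the gap to compound 3, its furthest, lies beyond the scatter as well. No two of the measured compounds differ in one place only, so no single step can be read off among them.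

Compound 4 `O=C(C(Nc1ccccc1F)c1ccc(C(F)(F)F)cc1)N1CCCC1c1ccncc1` is not yet measured. It follows from compound 2 by one change: pyridin-4-yl in place of 2-fluorophenyl on a saturated ring carbon. Among the compounds with values here, no measured pair shows this change, so what follows is expectation only. In this assay the change is expected to weaken inhibition, a rise beyond the scatter, a 5.7-fold higher number from compound 2 to compound 4 (0.76 log units; beyond the scatter). For compound 4 the estimate in this assay is 40 nM, with a range from 10 nM to 200 nM.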

Compound 4, half-maximal inhibitory concentration: 19 nM
Compound 4: the middle estimate sits 2.1-fold (0.32 log units) above what was measured; the measured number falls inside the stated range.
By their numbers in this assay, from the lowest: compound 2; then compound 4; then compounds 1 and 3 (each within the scatter of the next).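

Within the data shown here, this is the first single-place step: in this assay, pyridin-4-yl in place of 2-fluorophenyl on the saturated ring carbon next to the ring nitrogen gives a 2.7-fold higher number from compound 2 to compound 4 (0.43 log units; beyond the scatter) and so costs inhibition beyond the scatter, yet only modestly. The position therefore accepts a six-membered aromatic ring with 1 hetero atom, and compound 4 still reads 19 nM in this assay after the fluorine is lost and a ring nitrogen enters together. The two parts of this exchange cannot be separated on this single step, and no measurement at hand bears on the cause of the rise.

The compounds shown leave open how plain phenyl, pyridin-3-yl, pyridin-2-yl or a saturated piperidin-4-yl ring would stand at this carbon, and so whether the ring nitrogen or the missing fluorine sets the size of the step. Also open, on these data alone, is whether the same exchange gives a step of similar size when the other aromatic rings carry different substituents, as they do in compound 1 and compound 3.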